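The source may report more compounds than this note shows. Statements on the series, on what has been measured and on what is new or still open speak of the compounds shown alone.

The series shares one core, varied only at the benzylidene arm. Compound 1 `C=CCn1c(=O)/c(=C\c2cccc(Br)c2)[nH]c(=O)/c1=C\c1ccccc1OC` and compound 2 `C=CCn1c(=O)/c(=C\c2cccc(Cl)c2)[nH]c(=O)/c1=C\c1ccccc1OC` carry a halogen there; in a functional assay on U-937 cells (Homo sapiens) for cytotoxicity, read by CCK-8 assay, with a stated time of 72 h (on this read-out lower numbers stand for stronger inhibition and higher numbers for weaker inhibition), compound 1 gives 1100 nM and compound 2 gives 1200 nM. The step of a 1.1-fold higher number from compound 1 to compound 2 (0.04 log units; within the scatter) shows that exchanging chloro for bromo on this aromatic carbon leaves the read-out essentially where it was. Compound 3 `C=CCn1c(=O)/c(=C\c2ccc(C)cc2)[nH]c(=O)/c1=C\c1ccccc1OC`, with 4-methylphenyl in that position, is reported in this assay as "not active" (no number reported), so no single number is available for it, and it stands apart from compounds 1 and 2 on the numbers shown.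

Compound 4 `C=CCn1c(=O)/c(=C\c2ccc(Cl)c(Cl)c2)[nH]c(=O)/c1=C\c1ccccc1OC` has not yet been measured. It differs from compound 3 by 3,4-dichlorophenyl in place of 4-methylphenyl on a double-bonded chain carbon bound to an aromatic carbon. Among the measured compounds shown here, no measured step connects these two compounds, so only the neighbouring pairs can guide an expectation: compounds 1 and 2 show that a halogen on this ring sits around the low-micromolar range, while compound 3 shows that 4-methylphenyl gives no reported activity. Compound 4 carries a chlorine in the same position as compound 2 together with a second chlorine, so its activity in this assay is expected to return toward the range of compounds 1 and 2, with some chance that it again falls outside the measurable window. Compound 4 is therefore estimated at 2000 nM, in the range 600 nM to 8000 nM.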

Compound 4, half-maximal inhibitory concentration: "not active" (no number reported)
Compound 4: no number reported; the estimate stays without a comparison.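

Compound 3 and compound 4 are both reported as "not active" in this assay, with no number for either, so no step can be read between them. Nothing shown bears on the reason for this result. The compounds shown leave open how weak compound 3 and compound 4 actually are and what sets them apart from compound 1 and compound 2.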